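From 2-carboxypiperidin-1-yl to an open-chain amino acid tail

The source may hold more compounds than are shown below. What is called first, only, known or untested is meant among the compounds shown, and "the series" means these compounds.

Three members of the series are measured so far. Compound 1 `COc1ccc(/C=C\c2cc(OC)c(OC)c(OC)c2)cc1OCc1ccc(CN2CCCC[C@@H]2C(=O)O)cc1` carries a defined configuration at the ring carbon of its tail; in a functional assay on B16-F10 cells (Mus musculus) for antiproliferative activity, read by CCK-8 assay, with a stated time of 48 h (on this read-out lower numbers stand for stronger inhibition and higher numbers for weaker inhibition), compound 1 gives only a limit, > 10000 nM. Compound 2 `COc1ccc(/C=C\c2cc(OC)c(OC)c(OC)c2)cc1OCc1ccc(CN2CCCCC2C(=O)O)cc1` is the same structure drawn without that configuration; in this assay compound 2 likewise gives only a limit, > 10000 nM. Compound 3 `COc1ccc(/C=C\c2cc(OC)c(OC)c(OC)c2)cc1OCc1ccc(CN2CC[C@@H](C(=O)O)C2)cc1` carries 3-carboxypyrrolidin-1-yl instead; in this assay compound 3 also gives only a limit, > 10000 nM. Because the limit of > 10000 nM in this assay, at which 3 of the 3 values shown sit, none of the three steps can be sized: a step that the two limits leave unreadable from compound 1 to compound 2, a step that the two limits leave unreadable from compound 1 to compound 3 and a step that the two limits leave unreadable from compound 2 to compound 3 all remain unreadable, and the fact that one of compounds 1 and 2 is drawn with a defined configuration and the other without, at the place where they differ adds nothing that the numbers could resolve.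

Compound 4 `COc1ccc(/C=C\c2cc(OC)c(OC)c(OC)c2)cc1OCc1ccc(CN[C@H](C(=O)O)[C@@H](C)O)cc1` replaces the tail of compound 2 by an open chain: (1-carboxy-2-hydroxypropyl)amino in place of 2-carboxypiperidin-1-yl on a saturated chain carbon bound to an aromatic carbon. Among the measured compounds shown here, no measured step bears on this change with a readable size; the only guidance is that every tail variant so far sits at the limit. For compound 4 the expected step is therefore a step that the limit leaves unreadable from compound 2 to compound 4, with no direction beyond the scatter supported. Compound 4 is accordingly estimated at 12000 nM, within 2000 nM to 60000 nM, and another limit is the likeliest outcome.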

Compound 4, half-maximal inhibitory concentration: 5400 nM
Compound 4: the middle estimate sits 2.2-fold (0.35 log units) above what was measured; measured number inside the range.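

Among the compounds shown here, compound 4 is the first member of the series in this assay to give a number rather than a limit, so (1-carboxy-2-hydroxypropyl)amino is the first tail on this saturated chain carbon bound to an aromatic carbon that reads within the range of the assay. Against the ring tails the result shows an at least 1.8-fold lower number from compound 2 to compound 4 (0.26 log units; that floor lies within the scatter), an at least 1.8-fold lower number from compound 3 to compound 4 (0.26 log units; that floor lies within the scatter) and an at least 1.8-fold lower number from compound 1 to compound 4 (0.26 log units; that floor lies within the scatter); each of these is only a floor lying within the scatter, so the open chain cannot yet be called a real gain. The steps among compound 1, compound 2 and compound 3 remain unreadable, and the full size of the new steps stays unknown, because the ring tails give no number: the limit of > 10000 nM in this assay, at which 3 of the 4 values shown sit.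

The compounds shown leave open whether the number goes with the loss of the ring, with the hydroxyl group or with the defined stereocentres, as compound 4 changes all of these at once. A (carboxymethyl)amino tail without the hydroxyl group, or a methyl ester in place of the carboxylic acid, would bear on that question.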